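Phenyl to 4-fluorophenyl: notes on the series

A few compounds are considered here, and "the series" means these few. Any claim that something is new, unique, unknown or untested is made for them only; others in the source may bear on it.

Values in a functional assay on PC-3 cells (Homo sapiens) for cytotoxicity, read by MTT assay, with a stated time of 72 h; a lower number here means a stronger inhibitor, a higher number a weaker inhibitor:
- compound 1 `CC1=C(/C=C/C(=O)/C=C/c2ccccc2)C(C)(C)CCC1O`: 15500 nM
- compound 2 `CC1=C(/C=C/C(=O)/C=C/c2ccccc2C(F)(F)F)C(C)(C)CCC1O`: 3700 nM
- compound 3 `CC1=C(/C=C/C(=O)/C=C/c2ccc(F)cc2)C(C)(C)CCC1O`: not yet measured

Of the two measured compounds, compound 1 holds the higher number, 15500 nM, and so is the weaker inhibitor. Among the compounds with values here, the only neighbour is compound 2, and the gap is a 4.2-fold lower number from compound 1 to compound 2 (0.62 log units; beyond the scatter).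

The next step replaces hydrogen with fluoro on an aromatic carbon, para to a large group: fluoro in place of hydrogen on an aromatic carbon. Within the data shown here, only one measured step bears on this change, the trifluoromethyl replacement of hydrogen on an aromatic carbon, which gave a 4.2-fold lower number from compound 1 to compound 2 (0.62 log units; beyond the scatter). That step involves a different group, and a single step is thin support. Among the measured compounds shown here, a lower number in this assay is therefore expected only tentatively, with a smaller step than the one to compound 2, possibly one that stays within the scatter.

The expected change is a 1.7-fold lower number from compound 1 to compound 3 (0.24 log units; within the scatter). For compound 3 the estimated value is 9000 nM, with an expected range of 4000 nM to 20000 nM.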

Compound 3, half-maximal inhibitory concentration: 6200 nM
Compound 3: the middle estimate sits 1.5-fold (0.16 log units) above what was measured; the range from low to high includes it.
By their numbers in this assay, from the lowest: compounds 2 and 3 (each within the scatter of the next); then compound 1.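

In this assay, the step to fluoro, a 2.5-fold lower number from compound 1 to compound 3 (0.40 log units; beyond the scatter), shows that this aromatic carbon, para to a large group, responds to the entry of a single fluorine atom, and that the change lies beyond the scatter. With a 4.2-fold lower number from compound 1 to compound 2 (0.62 log units; beyond the scatter) already in hand, compound 1 now has two single replacements of aromatic hydrogen, fluoro and trifluoromethyl, and each gives a lower number; neither of the compounds shown goes against this, though two steps from one parent make only a narrow pattern. Nothing on hand explains why the fluoro step has this size, so the result stands as an observation only.

Open, on these data alone, is whether a chloro, a methoxy or an amine on this same aromatic carbon would also give a lower number than compound 1, or whether the trend is limited to fluorine-bearing groups. Also open, as far as these compounds go, is whether the fluoro step would keep its size on a core in which the hydroxyl of compound 1 gives way to a carbonyl.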